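The source may hold more compounds than are shown below. What is called first, only, known or untested is meant among the compounds shown, and "the series" means these compounds.

Compound 2 `CC1CCC(=NNc2ccc(Cl)c(Cl)c2)c2ncc(C(=O)O)c(=O)n21` holds the lower of the two numbers that have been measured in a functional assay on the whole organism with Rattus norvegicus as the target; a lower number here means that less compound is needed, a higher number that more compound is needed for the effect; its nearest neighbour is compound 1 `Cc1ccc(NN=C2CCC(C)n3c2ncc(C(=O)O)c3=O)cc1C`, and the gap between them is beyond the scatter. In this assay compound 1 gives 6.5 umol/kg, while compound 2 gives 0.89 umol/kg, the change being a 7.3-fold lower number from compound 1 to compound 2 (0.86 log units; beyond the scatter). Compound 3 `CC1CCC(=NNc2ccccn2)c2ncc(C(=O)O)c(=O)n21` has not yet been measured; it differs from compound 2 in one place only, (pyridin-2-yl in place of 3,4-dichlorophenyl on an amine nitrogen). For the measured compounds named here, the single measured step bears on this change only loosely: it shows that exchanging one six-membered carbon ring for another with different substituents moved the number by a modest amount, but no measured compound carries a ring with a hetero atom at this position, so the direction of the new change cannot be read from the pair at hand. Given that the pyridin-2-yl group brings a hydrogen-bond acceptor where the 3,4-dichlorophenyl group had none, and removes both chlorines, the step is expected to be a 2.8-fold higher number from compound 2 to compound 3 (0.45 log units; beyond the scatter), with little certainty. Compound 3 is therefore estimated at 2.5 umol/kg, within a range from 0.6 umol/kg to 12 umol/kg.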

Compound 3, dose for 50% inhibition: 3.2 umol/kg
For compound 3 the middle estimate is 1.3-fold (0.11 log units) below the measured one; the range from low to high includes it.
By their numbers in this assay, from the lowest: compound 2; then compound 3; then compound 1.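

The pyridin-2-yl group, the first ring with a hetero atom at this amine nitrogen, keeps a measurable effect in this assay, with a 3.6-fold higher number from compound 2 to compound 3 (0.56 log units; beyond the scatter). The same group also compares favourably with the other carbon ring, with a 2.0-fold lower number from compound 1 to compound 3 (0.31 log units; beyond the scatter), so compound 1 goes against any reading that a carbon ring gives the lower number at this position. The whole spread across the three compounds is therefore the one set by the two carbon-ring compounds, a 7.3-fold lower number from compound 1 to compound 2 (0.86 log units; beyond the scatter), and the choice of substituents on the carbon ring counts for at least as much here as the exchange of ring type. Nothing at hand explains this order of the numbers.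

The change from 3,4-dichlorophenyl to pyridin-2-yl removes the two chlorines and brings in the ring nitrogen in a single step, and the compounds shown cannot separate the two. An unsubstituted phenyl group would divide that step, while pyridin-3-yl or a chloropyridinyl group would show whether the value depends on the ring nitrogen's place or on the chlorine.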